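The source may hold more compounds than are shown below. What is called first, only, known or untested is meant among the compounds shown, and "the series" means these compounds.

The series is followed in an ADME assay on HEp-2 cells (Homo sapiens) for cytotoxicity; on this read-out lower numbers stand for higher toxicity in this test and higher numbers for lower toxicity in this test. Compound 1 `CC(C)CCn1c(Cn2c(=O)n(C(C)C)c3ccccc32)nc2cc(CN)ccc21` gives 3920 nM and stands at the lowest of the two numbers recorded so far. Compound 2 `COC(=O)c1cccc2nc(Cn3c(=O)n(C(C)C)c4ccccc43)n(CCC(C)C)c12` gives 25300 nM, a number far enough above that of compound 1 to lie beyond the scatter. Compound 3 `CC(C)CCn1c(Cn2c(=O)n(C(C)C)c3ccccc32)nc2cc(-c3nn[nH]n3)ccc21` has not yet been measured; it differs from compound 1 by 2H-tetrazol-5-yl in place of aminomethyl on an aromatic carbon. Within the data shown here, no step between measured compounds carries this change, and the two numbers at hand say nothing about it directly. The change is expected to move the number for compound 3 somewhat upward, that is toward lower toxicity in this test, though not clearly beyond the scatter. The step expected a 1.9-fold higher number from compound 1 to compound 3 (0.28 log units; within the scatter) rests on this reading alone. Compound 3 is estimated at 7500 nM in this assay, with a range from 3000 nM to 25000 nM.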

Compound 3, half-maximal cytotoxic concentration: 2000 nM
For compound 3 the middle estimate is 3.8-fold (0.57 log units) above the measured one, outside the stated range (below it).
By their numbers in this assay, from the lowest: compounds 3 and 1 (each within the scatter of the next); then compound 2.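

In this assay, placing 2H-tetrazol-5-yl in place of aminomethyl on this aromatic carbon gives a 2.0-fold lower number from compound 1 to compound 3 (0.29 log units; within the scatter) and so leaves the read-out without a separable change. This position of the shared core therefore accepts a five-membered aromatic ring with 4 hetero atoms in place of the smaller aminomethyl group, and the toxicity reading stays in the same range; the basis for this cannot be stated, as no supporting data bear on the result.

Open, going by these compounds, is whether a carboxylic acid, a nitrile or a longer aminoalkyl chain on this same aromatic carbon would also read like compound 1 and compound 3. Also open, on these data alone, is whether this likeness holds when the chain on the ring nitrogen of the core is replaced by a shorter alkyl chain or a benzyl group.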